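The source may report more compounds than this note shows. Statements on the series, on what has been measured and on what is new or still open speak of the compounds shown alone.

Compound 2, with the structure `O=C(Nc1ccc(-c2noc(-c3cccc(NS(=O)(=O)c4ccc(C(F)(F)F)cc4)c3)n2)c(Cl)c1)c1cccnc1`, is the starting point. In a functional assay on MDA-MB-231 cells (Homo sapiens) for antiproliferative activity, read by MTT assay, with a stated time of 72 h (a higher number here means a weaker inhibitor, a lower number a stronger inhibitor), compound 2 gives > 10000 nM, which is a limit of the assay and not a number. Its neighbour compound 1, with the structure `O=C(Nc1ccc(-c2noc(-c3cccc(NS(=O)(=O)c4ccccc4)c3)n2)c(Cl)c1)c1cccnc1`, differs from it only in carrying hydrogen where compound 2 carries trifluoromethyl on an aromatic carbon. In this assay compound 1 gives > 10000 nM, again a limit. Among the compounds with values here, the step that the two limits leave unreadable from compound 1 to compound 2 therefore cannot be read, and the only thing the pair establishes is the limit of > 10000 nM in this assay, at which 2 of the 2 values shown sit.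

The next compound, compound 3, has the structure `COc1cccc(S(=O)(=O)Nc2cccc(-c3nc(-c4ccc(NC(=O)c5cccnc5)cc4Cl)no3)c2)c1`. Its change from compound 2 is 3-methoxyphenyl in place of 4-(trifluoromethyl)phenyl on a sulfonyl sulfur. Within the data shown here, no measured step speaks to this exchange: the one step available, from compound 1 to compound 2, is hidden by two limits, so it gives no size and no direction. With both known compounds at the same limit, the expectation for compound 3 is no movement beyond the scatter, so the step that the limit leaves unreadable from compound 2 to compound 3 is expected to be near zero. Compound 3 is estimated to give 12000 nM, within 3000 nM and 40000 nM, most likely reported again only as a limit.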

Compound 3, half-maximal inhibitory concentration: > 10000 nM
Compound 3 gave a limit, no number; the forecaster's own chance of this, stated with the estimate: 80%; the middle value does not contradict the limit.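

Compound 3 also ends at a limit of the assay and not a number, so its steps from compound 1 and compound 2 cannot be read, and the three compounds share one result: the limit of > 10000 nM in this assay, at which 3 of the 3 values shown sit. The compounds shown leave open whether any group on the sulfonyl sulfur would give a measurable value in this assay.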